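This account rests on a few compounds, and the source may have more. Where it says the series, first, only, none or still open, it means among the compounds named here.

Working notes on the series. The shared core is that of compound 1 `C/C(=N\NC(N)=S)c1sc(C)nc1C`. In a toxicity assay on HCT-116 cells (Homo sapiens) for cytotoxicity, read by MTT assay (a lower number here means a stronger inhibitor of growth, a higher number a weaker inhibitor of growth), compound 1 gives > 100 ug/mL, which is a limit of the assay and not a number. Compound 2 `C/C(=N\Nc1nc(-c2ccc(F)cc2)cs1)c1sc(C)nc1C` is the larger analogue, carrying a 4-fluorophenyl. In this assay compound 2 gives > 100 ug/mL, again a limit rather than a measured number. Going by the values given here, both known values sit at the limit of > 100 ug/mL in this assay, at which 2 of the 2 values shown sit; no step between measured compounds can be read, and compound 2 stands at the same limit as compound 1, with nothing yet to separate the two. Compound 3 `COc1ccc(-c2csc(N/N=C(\C)c3sc(C)nc3C)n2)cc1` differs from compound 2 by methoxy in place of fluoro on an aromatic carbon. With both known values at the limit, a number no higher from compound 2 to compound 3 (the limit leaves the size open) is expected to be none beyond the scatter. Compound 3 is accordingly estimated at 100 ug/mL, within 40 ug/mL to 300 ug/mL, and it is expected that this assay again reports only a limit.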

Compound 3, concentration for 50% growth inhibition: > 100 ug/mL
Compound 3 gave a limit, no number; the forecaster's own chance of this, stated with the estimate: 80%; the middle value lies on the limit itself.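

In this assay, going by these compounds alone, compound 2 and compound 3 both stand at a limit and not a number, so no step between them can be read. The compounds shown leave open how 4-fluorophenyl and 4-methoxyphenyl compare in this assay and whether any analogue of the shared core gives a readable number.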